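Swapping the piperazinyl of compound 2 for an acetamido

The source may report more compounds than this note shows. Statements on the series, on what has been measured and on what is new or still open speak of the compounds shown alone.

Compound 1 `Cc1cc(C)cc(Cn2c(=O)cc(NC3CC3)n(Cc3ccccc3)c2=O)c1`: in an ADME assay on MT4 cells (Homo sapiens) for cytotoxicity, read by MTT assay, with a stated time of 4 days (on this read-out lower numbers stand for higher toxicity in this test and higher numbers for lower toxicity in this test), compound 1 gives > 100000 nM, which is a limit of the assay rather than a number.
Compound 2 `Cc1cc(C)cc(Cn2c(=O)cc(N3CCNCC3)n(Cc3ccccc3)c2=O)c1`: in this assay compound 2 gives 16000 nM.
Compound 3 `Cc1cc(C)cc(Cn2c(=O)cc(N)n(Cc3ccncc3)c2=O)c1`: in this assay compound 3 gives > 100000 nM, again a limit of the assay.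

Among these three, compound 2 is the only one with an actual number in this assay; the other two sit at the limit of > 100000 nM in this assay, at which 2 of the 3 values shown sit. Compound 4 `CC(=O)Nc1cc(=O)n(Cc2cc(C)cc(C)c2)c(=O)n1Cc1ccccc1` differs from compound 2 in one place: acetamido in place of piperazin-1-yl on an aromatic carbon. For the measured compounds named here, the one measured step that touches this position is an at least 6.2-fold lower number from compound 1 to compound 2 (0.79 log units; beyond the scatter), where bringing in the piperazin-1-yl was paired with a lower number. Taking the piperazin-1-yl out again, here for an acetamido, is therefore expected to move the number back up, and the step from compound 2 to compound 4 is estimated at a 5.0-fold higher number from compound 2 to compound 4 (0.70 log units; beyond the scatter). For compound 4 the expected value in this assay is 80000 nM, in a range from 25000 nM to 200000 nM, with a fair chance that only a limit is reported.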

Compound 4, half-maximal cytotoxic concentration: > 100000 nM
Compound 4: no number, only a limit; the forecaster's own chance of this, stated with the estimate: 60%; at least 1.2-fold (0.09 log units) between middle value and limit.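

In this assay, replacing the piperazin-1-yl with acetamido gives an at least 6.2-fold higher number from compound 2 to compound 4 (0.79 log units; beyond the scatter), so a second group at this position, after the cyclopropylamino, is paired with a higher number than the piperazin-1-yl. The true size of this step stays hidden, as the entry for compound 4 is a limit and not a number. Among the compounds that differ at this position, piperazin-1-yl is therefore the only group with a measured number, and the series mostly reads as limits: the limit of > 100000 nM in this assay, at which 3 of the 4 values shown sit.

The step between compound 1 and compound 4 cannot be read, as both entries are limits, so cyclopropylamino and acetamido cannot be ranked against each other. Also open, going by these compounds, is whether the lower number goes with the ring of piperazin-1-yl or with its second nitrogen; a morpholine or a 2-aminoethylamino group at this position would separate the two.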